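The source may hold more compounds than are shown below. What is called first, only, known or untested is meant among the compounds shown, and "the series" means these compounds.

Compound 2 `CC1(C)[C@H]2CC[C@]1(C)N(Cc1cn(-c3cccc(Br)c3)nn1)C(=O)C2` gives 10500 nM in an ADME assay on L02 cells (Homo sapiens) for cytotoxicity, read by MTT assay, with a stated time of 24 h (on this read-out lower numbers stand for higher toxicity in this test and higher numbers for lower toxicity in this test), the second highest of three numbers: compound 1 `CC1(C)[C@H]2CC[C@]1(C)N(Cc1cn(-c3ccccc3)nn1)C(=O)C2` gives 6230 nM, and compound 3 `CC1(C)[C@H]2CC[C@]1(C)N(Cc1cn(-c3ccccc3Cl)nn1)C(=O)C2` gives 20100 nM, both within the scatter of compound 2. Across these, a 1.7-fold higher number from compound 1 to compound 2 (0.23 log units; within the scatter) and a 1.9-fold higher number from compound 2 to compound 3 (0.28 log units; within the scatter) were within the scatter, and only a 3.2-fold higher number from compound 1 to compound 3 (0.51 log units; beyond the scatter) was a modest step beyond it. Compound 4 `CC1(C)[C@H]2CC[C@]1(C)N(Cc1cn(-c3ccc(C#N)cc3)nn1)C(=O)C2` differs from compound 2 by 4-cyanophenyl in place of 3-bromophenyl on an aromatic nitrogen. Among the compounds with values here, the one measured swap of a whole aryl group, a 1.9-fold higher number from compound 2 to compound 3 (0.28 log units; within the scatter), bears most directly on this, and it was small. No step beyond the scatter is therefore expected in this assay. Compound 4 is estimated at 10000 nM, within 4000 nM to 25000 nM, which is expected to mean a 1.1-fold lower number from compound 2 to compound 4 (0.02 log units; within the scatter).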

Compound 4, half-maximal cytotoxic concentration: 15700 nM
Compound 4: middle estimate off by 1.6-fold (0.20 log units), on the low side, within the range that was stated.
By their numbers in this assay, from the lowest: compounds 1, 2, 4 and 3 (each within the scatter of the next, the first and the last beyond it).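

In this assay, the 4-cyanophenyl group on the aromatic nitrogen stays within the scatter of both other substituted aryl groups (a 1.5-fold higher number from compound 2 to compound 4 (0.17 log units; within the scatter); a 1.3-fold lower number from compound 3 to compound 4 (0.11 log units; within the scatter)). Against the unsubstituted phenyl group, the cyano group gives a modest step (a 2.5-fold higher number from compound 1 to compound 4 (0.40 log units; beyond the scatter)), so cyano joins chloro in clearing the scatter, while bromo in compound 2 does not. No evidence here accounts for these numbers. The compounds shown leave open whether an amine or a carboxylic acid on the phenyl ring would move the number beyond the scatter of these aryl groups.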